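The source may hold more compounds than are shown below. What is called first, only, known or untested is meant among the compounds shown, and "the series" means these compounds.

Compound 1 `O=S(=O)(NCCCNc1nccc(-c2c(-c3cccc(F)c3)nc3sccn23)n1)c1ccc(Cl)cc1` gives 8450 nM in a functional assay on SK-MEL-28 cells (Homo sapiens) for cytotoxicity, read by MTT assay; on this read-out higher numbers stand for weaker inhibition and lower numbers for stronger inhibition.
Compound 2 `O=C(NCCNc1nccc(-c2c(-c3cccc(F)c3)nc3sccn23)n1)c1ccc(Cl)cc1` gives 8160 nM in this assay.
Compound 3 `O=S(=O)(NCCNc1nccc(-c2c(-c3cccc(F)c3)nc3sccn23)n1)c1cccc(F)c1` gives 18300 nM in this assay.

Compound 3 holds the highest number of the three; the steps leading to it were a 2.2-fold higher number from compound 1 to compound 3 (0.34 log units; beyond the scatter) and a 2.2-fold higher number from compound 2 to compound 3 (0.35 log units; beyond the scatter), both modest and both beyond the scatter. Compound 4 `O=C(NCCCNc1nccc(-c2c(-c3cccc(F)c3)nc3sccn23)n1)c1ccc(F)cc1` differs from compound 3 by (((4-fluorophenyl)carbonyl)amino)methyl in place of ((3-fluorophenyl)sulfonyl)amino on a saturated chain carbon, two bonds along the chain from a nitrogen on an aromatic ring. This change reverses both measured steps at once: the amide replaces the sulfonamide and the three-carbon chain returns, so a modest fall in the number is expected. Among the compounds with values here, no measured pair shows fluorine against chlorine on that ring, so that part is unresolved. Compound 4 is therefore expected at 9000 nM, between 3000 nM and 27000 nM. The expected step is a 2.0-fold lower number from compound 3 to compound 4 (0.31 log units; beyond the scatter).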

Compound 4, half-maximal inhibitory concentration: > 20000 nM
Compound 4 was reported as a limit (the forecaster's own chance of this, stated with the estimate: 5%); at least 2.2-fold (0.34 log units) between middle value and limit.
By their numbers in this assay, from the lowest: compounds 2 and 1 (each within the scatter of the next); then compound 3. At a limit, above all of these: compound 4.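

Compound 4 is reported only as a limit, > 20000 nM. Within the data shown here, at this place, (((4-fluorophenyl)carbonyl)amino)methyl gives no number near those of the earlier compounds: there is an at least 2.4-fold higher number from compound 2 to compound 4 (0.38 log units; beyond the scatter) and an at least 2.3-fold higher number from compound 1 to compound 4 (0.37 log units; beyond the scatter). Against ((3-fluorophenyl)sulfonyl)amino, the change gives an at least 1.0-fold higher number from compound 3 to compound 4 (0.03 log units; that floor lies within the scatter), so this change brings no lower number and compound 3 and compound 4 cannot be put in order.

The compounds shown do not separate the effect of fluorine from that of chlorine on the ring of the amide. On these data alone, how a methoxy group or bromine there, or a longer chain, would read stays open.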